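Working notes: swapping the aryl group on the shared core

The source may report more compounds than this note shows. Statements on the series, on what has been measured and on what is new or still open speak of the compounds shown alone.

Measured in an ADME assay on HEK293 cells (Homo sapiens) for inhibition, read by MTT assay, with a stated time of 48 h; a lower number here means a stronger inhibitor, a higher number a weaker inhibitor:
Compound 1 `CCc1ccc(-c2nc3ccccn3c2Sc2ccccc2)cc1`: > 100000 nM (a limit)
Compound 2 `N#Cc1ccc(-c2nc3ccccn3c2Sc2ccccc2)cc1`: > 100000 nM (a limit)

Neither compound has a numerical value yet. Compound 2 stands at > 100000 nM, which is a limit. Among the compounds with values here, the same holds across the series so far, which shows (the limit of > 100000 nM in this assay, at which 2 of the 2 values shown sit).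

The next change gives compound 3 `c1ccc(Sc2c(-c3cccs3)nc3ccccn23)cc1`: thiophen-2-yl in place of 4-cyanophenyl on an aromatic carbon, (thiophen-2-yl in place of 4-cyanophenyl on an aromatic carbon). Within the data shown here, the group that leaves is replaced directly on the core, so this is a larger exchange than the only measured step.

That step is a step that the two limits leave unreadable from compound 1 to compound 2, cyano in place of ethyl on an aromatic carbon. It offers no size or direction to carry over. With nothing in the series pointing to a gain, no step beyond the scatter is expected in this assay, and the most likely outcome is another limit.

The expected change is a number no higher from compound 2 to compound 3 (the limit leaves the size open). Compound 3 is estimated at 100000 nM, with an expected range of 30000 nM to 200000 nM.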

Compound 3, half-maximal inhibitory concentration: > 100000 nM
Compound 3: only a limit was reported (the forecaster's own chance of this, stated with the estimate: 80%); the middle value lies on the limit itself.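

In this assay, within the data shown here, compound 3 gives > 100000 nM, a limit, and no step from compound 1 or compound 2 to compound 3 can be read. The compounds shown leave open how strongly any of the three inhibits, and whether exchanging the aryl group on the shared core changes the read-out at all, with the series showing only: the limit of > 100000 nM in this assay, at which 3 of the 3 values shown sit.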